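Hydroxy to methyl in a series without clear steps

The source may hold more compounds than are shown below. What is called first, only, known or untested is meant among the compounds shown, and "the series" means these compounds.

compound 1 `CC1(C)[C@H]2CC[C@]1(C)N(Cc1cn(-c3ccc(C#N)cc3)nn1)C(=O)C2` gives 50 nM
compound 2 `CC1(C)[C@H]2CC[C@]1(C)N(Cc1cn(-c3ccc(F)cc3)nn1)C(=O)C2` gives 90 nM
compound 3 `CC1(C)[C@H]2CC[C@]1(C)N(Cc1cn(-c3ccc(O)cc3)nn1)C(=O)C2` gives 80 nM

These numbers come from a functional assay on HepG2 cells (Homo sapiens) for inhibition, read by MTT assay, with a stated time of 24 h (a higher number here means a weaker inhibitor, a lower number a stronger inhibitor), and the three compounds differ only in one group on the aromatic ring. Compound 3 gives 80 nM and lies within the scatter of both other compounds, so it holds no clear rank among them. Compound 4 `Cc1ccc(-n2cc(CN3C(=O)C[C@@H]4CC[C@@]3(C)C4(C)C)nn2)cc1` keeps the shared core and carries methyl in place of hydroxy on an aromatic carbon. For the measured compounds named here, no methyl compound has been measured yet, so the guide is the swaps already made at this place. Going from cyano to fluoro gave a 1.8-fold higher number from compound 1 to compound 2 (0.26 log units; within the scatter) and going from cyano to hydroxy gave a 1.6-fold higher number from compound 1 to compound 3 (0.20 log units; within the scatter) while going from fluoro to hydroxy gave a 1.1-fold lower number from compound 2 to compound 3 (0.05 log units; within the scatter) as well. With all three steps that small, no step beyond the scatter is expected in this assay in either direction. The estimated change is no change at the digits printed from compound 3 to compound 4 (within the scatter) and thus stays small. For compound 4 the estimated value is 80 nM with an expected range from 35 nM to 180 nM in most repeat measurements.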

Compound 4, half-maximal inhibitory concentration: 480 nM
Compound 4: the middle estimate sits 6.0-fold (0.78 log units) below what was measured; the whole stated range lies below it.
By their numbers in this assay, from the lowest: compounds 1, 3 and 2 (each within the scatter of the next); then compound 4.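

This place on the aromatic ring is not indifferent to what sits there: in this assay, methyl in place of hydroxy gives a 6.0-fold higher number from compound 3 to compound 4 (0.78 log units; beyond the scatter) and so breaks from the flat picture left by the first three compounds. The same break appears against the other two groups, with a 5.3-fold higher number from compound 2 to compound 4 (0.73 log units; beyond the scatter) for methyl in place of fluoro and a 9.6-fold higher number from compound 1 to compound 4 (0.98 log units; beyond the scatter) for methyl in place of cyano, so compound 4 stands apart while compounds 1, 2 and 3 stay within the scatter of one another. Nothing measured here accounts for why methyl stands apart from the other three groups.

Going by these compounds, with one methyl compound, it remains open whether this weaker result belongs to methyl alone or extends to an ethyl or trifluoromethyl group. On these data alone, it also remains open whether an amine or a methoxy group would fall with compounds 1, 2 and 3 or with compound 4.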